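The source may hold more compounds than are shown below. What is called first, only, known or untested is meant among the compounds shown, and "the series" means these compounds.

Measured so far in a functional assay on K562 cells (Homo sapiens) for inhibition, read by fluorescence, with a stated time of 72 h; a higher number here means a weaker inhibitor of growth, a lower number a stronger inhibitor of growth:

compound 1 `CC(C)c1nc(-c2ccccc2)cc2nn(-c3ccccc3)cc12`: 36800 nM
compound 2 `c1ccc(-c2cc3nn(-c4ccccc4)cc3cn2)cc1`: 3400 nM
compound 3 `Cc1nc(-c2ccccc2)cc2nn(-c3ccccc3)cc12`: 6300 nM

Compound 1 stands highest of the three numbers in this assay. Its nearest neighbour is compound 3, reached by a 5.8-fold lower number from compound 1 to compound 3 (0.77 log units; beyond the scatter); the furthest is compound 2, reached by an 11-fold lower number from compound 1 to compound 2 (1.03 log units; beyond the scatter). Between compound 2 and compound 3 the step is a 1.9-fold higher number from compound 2 to compound 3 (0.27 log units; within the scatter).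

Compound 4 `CCCCc1cc2nn(-c3ccccc3)cc2c(C(C)C)n1` differs from compound 1 as follows: butyl in place of phenyl on an aromatic carbon. The isopropyl group of compound 1 is kept. Among the compounds with values here, none of the measured steps touches the position changed here; all three concern the isopropyl carbon, so they give no direct reading on the size or direction of this change. The only usable anchor is that compound 1, the parent of compound 4, sits at the weak end of the series. The expectation for compound 4 is therefore a number near that of compound 1, with wide uncertainty and a fair chance of only a limit being reported. Compound 4 is estimated at 45000 nM, range 12000 nM to 170000 nM. This estimate corresponds to an expected step of a 1.2-fold higher number from compound 1 to compound 4 (0.09 log units; within the scatter).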

Compound 4, concentration for 50% growth inhibition: 12900 nM
For compound 4 the middle estimate is 3.5-fold (0.54 log units) above the measured one; the range from low to high includes it.
By their numbers in this assay, from the lowest: compounds 2 and 3 (each within the scatter of the next); then compound 4; then compound 1.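

In this assay, butyl in place of phenyl on the aromatic carbon next to the ring nitrogen gives a 2.9-fold lower number from compound 1 to compound 4 (0.46 log units; beyond the scatter), so this position can change the number while the isopropyl group is kept. With isopropyl present, the phenyl ring is not needed to retain growth inhibition, as an open chain with no ring gives a lower number rather than a loss of activity. No measurement offered here accounts for this step.

The butyl group is shown only alongside the isopropyl group, so whether the step carries over to the cores of compound 2 and compound 3 stays open. Also open, from the compounds shown here alone, is how a longer chain, a cyclohexyl ring or an amine in place of phenyl would read at this position.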